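Series notes: compound 3 to compound 4 in this assay

A few compounds are considered here, and "the series" means these few. Any claim that something is new, unique, unknown or untested is made for them only; others in the source may bear on it.

Compound 3 `CC(C)=CCN(C)C1CCN(CCCc2c[nH]c3ccc(-n4cnnc4)cc23)CC1` stands highest of the three measured compounds in a functional assay on CHO cells for activation of 5-hydroxytryptamine receptor 1D (Homo sapiens), read by GTPgammaS binding (on this read-out lower numbers stand for smaller maximal responses and higher numbers for larger maximal responses), where compound 3 gives 115%. Compound 1 `c1cc(CNC2CCN(CCCc3c[nH]c4ccc(-n5cnnc5)cc34)CC2)co1` gives 65% and compound 2 `NC(=O)OC[C@H](NC1CCN(CCCc2c[nH]c3ccc(-n4cnnc4)cc23)CC1)c1ccccc1` gives 73% in this assay. Between them, the step of a number 8 percentage points higher from compound 1 to compound 2 (within the scatter) lies within the scatter, whereas a number 50 percentage points higher from compound 1 to compound 3 (beyond the scatter) is large.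

Compound 4 `CC(CO)(NC1CCN(CCCc2c[nH]c3ccc(-n4cnnc4)cc23)CC1)c1ccccc1` differs from compound 3 at a saturated ring carbon: (1-(hydroxymethyl)-1-phenylethyl)amino in place of methyl(3-methylbut-2-en-1-yl)amino on a saturated ring carbon. The group that leaves has 0 hydrogen-bond donors; the group that enters has 2 hydrogen-bond donors and a six-membered aromatic ring, which brings compound 4 nearer in its make-up to compound 2 than to compound 3. The bearing steps are a number 50 percentage points higher from compound 1 to compound 3 (beyond the scatter), taken in reverse, and the small a number 8 percentage points higher from compound 1 to compound 2 (within the scatter), which shows that two such groups with an aromatic ring and a hydrogen-bond donor sit close together in this assay. A downward step is therefore expected, a number 40 percentage points lower from compound 3 to compound 4 (beyond the scatter). For compound 4 the estimate in this assay is 75%, within 55% to 100%.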

Compound 4, largest response reached (reported as efficacy), in percent of the reference or control that the assay uses: 59%
Compound 4: the middle estimate sits 16 percentage points above what was measured, within the range that was stated.
By their numbers in this assay, from the lowest: compounds 4, 1 and 2 (each within the scatter of the next, the first and the last beyond it); then compound 3.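

In this assay, the change on the saturated ring carbon gives a number 56 percentage points lower from compound 3 to compound 4 (beyond the scatter), which adds a third group with a six-membered aromatic ring or furan ring and an amine hydrogen to those well under compound 3. The two phenyl-bearing groups are not equivalent here, with a number 14 percentage points lower from compound 2 to compound 4 (beyond the scatter), while the furan-bearing group and 1-(hydroxymethyl)-1-phenylethyl cannot be told apart, with a number 6 percentage points lower from compound 1 to compound 4 (within the scatter). No measurement available gives a reason for these steps.

Compound 3 alone carries a methyl on this amine nitrogen, so the methyl and the 3-methylbut-2-en-1-yl group cannot be separated. The compounds shown leave open how (3-methylbut-2-en-1-yl)amino or methyl((furan-3-yl)methyl)amino would stand in this read-out.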